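Chloro for Bromo on a Scaffold Inactive Toward HepG2 Cells

The compounds below may be only part of what the source reports. "The series", "measured", "known", "first", "only" and "open" are said of these compounds alone.

Compound 1, `COc1cc(C(=O)C2Sc3nnc(-c4cc(OC)c(OC)c(OC)c4)n3NC2c2ccco2)cc(OC)c1OC`, in a functional assay on HepG2 cells (Homo sapiens) for cytotoxicity, read by MTT assay, with a stated time of 48 h (on this read-out higher numbers stand for weaker inhibition and lower numbers for stronger inhibition), gives only the assay limit > 100000 nM.
Compound 2, `COc1cc(-c2nnc3n2NC(c2ccco2)C(C(=O)c2ccc(Br)cc2)S3)cc(OC)c1OC`, in this assay gives only the assay limit > 100000 nM.

Both measured compounds share one core and differ only in the aryl group on the carbonyl carbon. Neither reaches a measurable value: the step that the two limits leave unreadable from compound 1 to compound 2 cannot be read, since both ends are limits. All that the numbers show is the limit of > 100000 nM in this assay, at which 2 of the 2 values shown sit, so compound 2 stands at the limit with no number of its own.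

Compound 3, `COc1cc(-c2nnc3n2NC(c2ccco2)C(C(=O)c2ccc(Cl)cc2)S3)cc(OC)c1OC`, is the next step. It keeps everything of compound 2 except one atom: chloro in place of bromo on an aromatic carbon. No measured step describes a swap of one halogen for another here; the only step shown, from a trimethoxyphenyl to a bromophenyl group, is itself unreadable. Because compound 2 sits at the limit of > 100000 nM in this assay, at which 2 of the 2 values shown sit, the most likely outcome is that compound 3 again reports only the limit. The expected step that the limit leaves unreadable from compound 2 to compound 3 is therefore none beyond the scatter. Compound 3 is estimated at 150000 nM, within 50000 nM to 500000 nM.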

Compound 3, half-maximal inhibitory concentration: 78600 nM
Compound 3: middle estimate off by 1.9-fold (0.28 log units), on the high side, within the range that was stated.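

In this assay, for the compounds shown here, compound 3 gives 78600 nM, the first actual number on this shared core, so a group on this carbonyl carbon can give a reading inside the range of the assay. Chloro in place of bromo gives an at least 1.2-fold lower number from compound 2 to compound 3 (0.10 log units; that floor lies within the scatter), and 4-chlorophenyl in place of 3,4,5-trimethoxyphenyl gives an at least 1.2-fold lower number from compound 1 to compound 3 (0.10 log units; that floor lies within the scatter); each of these is only a floor, so either change may be no larger than the scatter, or it may be larger, and the numbers cannot tell which. The step between compound 1 and compound 2 still cannot be read, as each of them stops at a limit and not at a number: the limit of > 100000 nM in this assay, at which 2 of the 3 values shown sit.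

The compounds shown leave open whether swapping one halogen for another on this aromatic carbon matters at all, since the true value of compound 2 is unknown. From the compounds shown here alone, how a fluoro or an amino group on that same carbon would read also stays open, as does whether any group there can bring the number far under that of compound 3.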